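This account rests on a few compounds, and the source may have more. Where it says the series, first, only, none or still open, it means among the compounds named here.

Compound 1, `CCN(Cc1cccc(Br)c1)c1ccc(C(=O)N2CCc3ccc(OS(N)(=O)=O)cc3C2)cc1`, gives 1.93 in a physicochemical assay for lipophilicity; on this read-out higher numbers stand for higher lipophilicity and lower numbers for lower lipophilicity. It stands level with its two measured neighbours: compound 2, `CC(C)CCN(CCC(C)C)c1ccc(C(=O)N2CCc3ccc(OS(N)(=O)=O)cc3C2)cc1`, gives 1.93, and compound 3, `NS(=O)(=O)Oc1ccc2c(c1)CN(C(=O)c1ccc(N3CCN(c4ncccn4)CC3)cc1)CC2`, gives 1.93. Among the compounds with values here, the one step recorded within this set, no change at the digits printed from compound 1 to compound 2 (within the scatter), shows that swapping the whole amine substituent for diisopentylamino left the read-out where it was; the values of compound 1 and compound 3 likewise sit together within the scatter.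

The compound now in question is compound 4, `CCN(Cc1ccncc1)c1ccc(C(=O)N2CCc3ccc(OS(N)(=O)=O)cc3C2)cc1`. It differs from compound 1 in a single place: pyridin-4-yl in place of 3-bromophenyl on a saturated chain carbon bound to a nitrogen on an aromatic ring. Within the data shown here, none of the measured steps covers this particular exchange; the step from compound 1 to compound 2 altered the groups on the aromatic nitrogen, while here the ethyl is kept and only the aryl on the benzylic carbon is replaced, with one bromine leaving and one hydrogen-bond acceptor entering.

Without a direct precedent, the author sets an expectation from the counted difference alone and expects a downward step of a number 1.23 log units lower from compound 1 to compound 4 (beyond the scatter) in this assay for compound 4. His estimate for compound 4 is therefore 0.7, expected to fall between 0 and 1.5.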

Compound 4, partition coefficient: 1.93
The estimate for compound 4 lay 1.23 log units below the measured number; the whole stated range lies below it.
By their numbers in this assay, from the lowest: compounds 1, 2, 3 and 4 (each within the scatter of the next).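

In this assay, pyridin-4-yl in place of 3-bromophenyl on a saturated chain carbon bound to a nitrogen on an aromatic ring gives no change at the digits printed from compound 1 to compound 4 (within the scatter). Within the data shown here, this is the first step at this place in which the ethyl stays and only the aromatic ring is exchanged, and neither the departure of the bromine nor the arrival of a hydrogen-bond acceptor shows in the number. The step on the aromatic carbon, ethyl((pyridin-4-yl)methyl)amino in place of diisopentylamino, gives no change at the digits printed from compound 2 to compound 4 (within the scatter), while no measurement offered here accounts for these matching numbers.

The compounds shown leave open whether the number would hold if this place carried something other than an aromatic ring, such as a carboxylic acid or a dimethylamino group, or another ring such as pyridin-2-yl. They also leave open whether a longer chain, such as butyl, in place of the ethyl would give the same number when pyridin-4-yl is kept.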